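Bromo for Fluoro on the Sulfonyl Aryl of Compound 2

The compounds below may be only part of what the source reports. "The series", "measured", "known", "first", "only" and "open" are said of these compounds alone.

Compound 1 `CN1CCN(c2ccc(C3=NN(C(=O)c4ccc(C(F)(F)F)cc4)C(c4ccc(N(C)C)cc4)C3)cc2)CC1` is measured in a functional assay on A549 cells (Homo sapiens) for inhibition (on this read-out higher numbers stand for weaker inhibition and lower numbers for stronger inhibition), only as a limit, > 10000 nM. Compound 2 `CN1CCN(c2ccc(C3=NN(S(=O)(=O)c4ccc(F)cc4)C(c4ccc(N(C)C)cc4)C3)cc2)CC1` gives 9600 nM, the only number shown. The other value shown belongs to compound 1 and is a limit (the limit of > 10000 nM in this assay, at which 1 of the 2 values shown sits). For the measured compounds named here, the single measured step, an at least 1.0-fold lower number from compound 1 to compound 2 (0.01 log units; that floor lies within the scatter), lies within the scatter. Compound 3 `CN1CCN(c2ccc(C3=NN(S(=O)(=O)c4ccc(Br)cc4)C(c4ccc(N(C)C)cc4)C3)cc2)CC1` carries bromo in place of fluoro on an aromatic carbon. Going by the values given here, no measured step touches this halogen swap, so no move beyond the scatter is expected, and compound 3 is estimated at 9000 nM, between 3000 nM and 30000 nM, meaning an expected step of a 1.1-fold lower number from compound 2 to compound 3 (0.03 log units; within the scatter).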

Compound 3, half-maximal inhibitory concentration: > 10000 nM
Compound 3: no number, only a limit; the forecaster's own chance of this, stated with the estimate: 45%; middle value at least 1.1-fold (0.04 log units) away from the limit.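

In this assay compound 3 gives only a limit, > 10000 nM. Bromo in place of fluoro on this aromatic carbon gives an at least 1.0-fold higher number from compound 2 to compound 3 (0.01 log units; that floor lies within the scatter), so this change brings no stronger inhibition at this position, and the true size of the step stays hidden; the step between compound 1 and compound 3 cannot be read. The compounds now gather at one ceiling: the limit of > 10000 nM in this assay, at which 2 of the 3 values shown sit.

On these data alone, it remains open whether an amine or a carboxylic acid at this position, in place of the halogen, would give a clearly lower number.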